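Second naphthalen-1-yl replacement in the series

The compounds below may be only part of what the source reports. "The series", "measured", "known", "first", "only" and "open" are said of these compounds alone.

Compound 1 `O=Cc1ccc(-c2cn3ccnc3c(-c3ccc4ncn(C5CCCCC5)c4c3)n2)cc1` gives 27.8% in a functional assay on SK-MEL-2 cells (Homo sapiens) for inhibition, read by sulforhodamine B assay, with a stated time of 48 h, tested at 10 uM; on this read-out lower numbers stand for less inhibition and higher numbers for more inhibition at the one concentration tested (going by the name of the read-out). Compound 2 `c1ccc2c(-c3cn4ccnc4c(-c4ccc5ncn(C6CCCCC6)c5c4)n3)cccc2c1` gives 2.3% in this assay; the change naphthalen-1-yl in place of 4-formylphenyl on an aromatic carbon made the step of a number 25.5 percentage points lower from compound 1 to compound 2 (beyond the scatter). Compound 3 `O=Cc1ccc(-c2cn3ccnc3c(-c3ccc4ncn(Cc5ccccc5)c4c3)n2)cc1` gives 27.8% in this assay; its core differs from the core of compound 1 by benzyl in place of cyclohexyl on an aromatic nitrogen, and that difference made the step of no change at the digits printed from compound 1 to compound 3 (within the scatter). Compound 4 `c1ccc(Cn2cnc3ccc(-c4nc(-c5cccc6ccccc56)cn5ccnc45)cc32)cc1` is not yet measured. It differs from compound 3 by naphthalen-1-yl in place of 4-formylphenyl on an aromatic carbon, the same change as from compound 1 to compound 2, at a place described in the same words; among the compounds shown this change occurs twice, once with a measurement. Because compound 1 moved by a number 25.5 percentage points lower from compound 1 to compound 2 (beyond the scatter) and compound 3 stands at 27.8%, compound 4 is expected to give about 3% in this assay, within -8% to 15%. The step from compound 3 is thus estimated at a number 24.8 percentage points lower from compound 3 to compound 4 (beyond the scatter).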

Compound 4, a percentage reported as inhibition, at one concentration (the size of the read-out at that concentration, not a potency): 17%
Beside the measured number, compound 4's estimate is 14 percentage points below it, outside the stated range (above it).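

In this assay, naphthalen-1-yl in place of 4-formylphenyl lowers the number on both cores, but the size of the step does not carry over, with a number 10.8 percentage points lower from compound 3 to compound 4 (beyond the scatter) set against the earlier step: the same change on two cores in this assay, a number 25.5 percentage points lower (beyond the scatter) from compound 1 to compound 2 and a number 10.8 percentage points lower (beyond the scatter) from compound 3 to compound 4, 14.7 percentage points apart, beyond the scatter of two such steps. Benzyl in place of cyclohexyl also depends on the other group, with a number 14.7 percentage points higher from compound 2 to compound 4 (beyond the scatter) and no matching step on the 4-formylphenyl pair: the same change on two cores in this assay, no change at the digits printed (within the scatter) from compound 1 to compound 3 and a number 14.7 percentage points higher (beyond the scatter) from compound 2 to compound 4, 14.7 percentage points apart, beyond the scatter of two such steps. The direction of the naphthalen-1-yl change held on these two cores, but four compounds show neither why the sizes differ nor how the change behaves on other cores.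

The compounds shown leave open how a phenyl carrying a carboxylic acid or an amine would compare with 4-formylphenyl, and how a longer alkyl chain would compare with benzyl or cyclohexyl. Potency also remains open, as each number comes from a single concentration.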